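A few compounds are considered here, and "the series" means these few. Any claim that something is new, unique, unknown or untested is made for them only; others in the source may bear on it.

Compound 1 `ClCc1ccc(Cn2cnc3nc(Cl)nc(Cl)c32)cc1` is a fused two-ring core carrying two chloro groups and a benzyl arm that ends in a chloromethyl group. In a functional assay on SK-MEL-5 cells (Homo sapiens) for cytotoxicity, read by sulforhodamine B assay, with a stated time of 48 h (a higher number here means a weaker inhibitor of growth, a lower number a stronger inhibitor of growth), compound 1 gives 9120 nM. Among the measured compounds shown here, the only comparison at hand is compound 2 `Nc1nc(Cl)c2ncn(Cc3cccc(CCl)c3)c2n1`, in which an amino group stands in place of one chloro group and the chloromethyl group sits on a different position of the benzyl ring; in this assay compound 2 gives 23400 nM, a higher number than that of compound 1 and beyond the scatter, so compound 1 holds the lower of the two numbers. Compound 3 `ClCc1ccc(Cn2cnc3ncnc(Cl)c32)cc1` is compound 1 with one change: hydrogen in place of chloro on an aromatic carbon. For the measured compounds named here, no measured pair shows this exact change, so no firm size can be drawn from it; the expectation is a small step, a 1.5-fold higher number from compound 1 to compound 3 (0.19 log units; within the scatter), slightly toward a weaker inhibitor of growth. Compound 3 is therefore estimated at 14000 nM, within a range from 5000 nM to 40000 nM.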

Compound 3, concentration for total growth inhibition: 12000 nM
The estimate for compound 3 lay 1.2-fold (0.07 log units) above the measured number; measured number inside the range.
By their numbers in this assay, from the lowest: compounds 1, 3 and 2 (each within the scatter of the next, the first and the last beyond it).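

Hydrogen in place of the chloro group on the aromatic carbon between two ring nitrogen atoms gives, in this assay, a 1.3-fold higher number from compound 1 to compound 3 (0.12 log units; within the scatter). Among the compounds shown here, this is the first comparison here that differs in one place only, and it shows that compound 1 and compound 3 cannot be told apart in this assay, so this chloro group is not required for the growth inhibition seen with compound 1. Nothing measured here gives a reason for this result.

As far as these compounds go, whether an amine, a methoxy group or a longer chain on this same carbon would also leave the number within the scatter remains open. Also open, from the compounds shown here alone, is what the other chloro group and the chloromethyl group each contribute, as compound 2 differs from compound 1 in more than one place and cannot settle this.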